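The source may hold more compounds than are shown below. What is called first, only, known or untested is meant among the compounds shown, and "the series" means these compounds.

In a functional assay on A549 cells (Homo sapiens) for inhibition, read by CCK-8 assay, with a stated time of 72 h, tested at 2 uM (on this read-out lower numbers stand for less inhibition of growth and higher numbers for more inhibition of growth at the one concentration tested), compound 1 `Nc1ccccc1NC(=O)/C=C/c1ccc(CSc2ccc(Cl)cc2)cc1` gives 55.3%, compound 2 `Nc1ccccc1NC(=O)/C=C/c1ccc(CSc2cccc(F)c2)cc1` gives 50.7% and compound 3 `Nc1ccccc1NC(=O)c1ccc(CSc2cccc(F)c2)cc1` gives 46.9%. Compound 2 stands second of the three numbers, with the gaps to compound 3 and to compound 1 both within the scatter. Compound 4 `Nc1ccccc1NC(=O)/C=C/c1ccc(CSCCc2ccccc2)cc1` is not yet measured; the change is phenethyl in place of 3-fluorophenyl on a sulfur. Going by the values given here, only one measured step touches the group on the sulfur: a number 4.6 percentage points lower from compound 1 to compound 2 (within the scatter), an exchange of one halogenated phenyl ring for another. Nothing measured trades a phenyl ring on the sulfur for a phenethyl, so no step beyond the scatter is expected, and the estimated step is a number 2.7 percentage points lower from compound 2 to compound 4 (within the scatter). For compound 4 in this assay the expected value is 48%, with a range from 34% to 62%, kept wide because the step of a number 4.6 percentage points lower from compound 1 to compound 2 (within the scatter) covers only a halogen exchange.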

Compound 4, percent growth inhibition at one concentration: 45.7%
Beside the measured number, compound 4's estimate is 2.3 percentage points above it, and the stated range covers the measured number.
By their numbers in this assay, from the lowest: compounds 4, 3, 2 and 1 (each within the scatter of the next).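

Phenethyl on the sulfur, in this assay, gives a number 5 percentage points lower from compound 2 to compound 4 (within the scatter) and a number 9.6 percentage points lower from compound 1 to compound 4 (within the scatter). The earlier compounds shown here only exchanged one halogenated phenyl ring for another, whereas compound 4 puts a two-carbon chain before the ring and carries no halogen, and neither step leaves the scatter. No measurement on hand gives a reason for these steps.

Open remain a chain longer than phenethyl on the sulfur and a group without an aromatic ring there, such as an amine or a carboxylic acid.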